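From Carbamoyl to Carboxy: Expectation for Compound 3

This account rests on a few compounds, and the source may have more. Where it says the series, first, only, none or still open, it means among the compounds named here.

Measured compounds:
compound 1 `NC(=O)/C=C/c1ccncc1-c1ccc2ccccc2c1`: 12100 nM
compound 2 `NC(=O)/C=C/c1ccncc1Br`: "not determined" (no result reported)

Going by the values given here, in a functional assay on HCT-116 cells (Homo sapiens) for inhibition, read by MTT assay, with a stated time of 72 h (on this read-out higher numbers stand for weaker inhibition of growth and lower numbers for stronger inhibition of growth), compound 1 gives 12100 nM, the only number in hand, while compound 2 in this assay stands as "not determined" (no result reported). Compound 3 `O=C(O)/C=C/c1ccncc1-c1ccc2ccccc2c1` differs from compound 1 in one place: hydroxy in place of amino on a carbonyl carbon. Among the compounds with values here, no step between two measured compounds exists to calibrate this change, so the expectation rests on compound 1 alone. The author expects the step of a 2.5-fold higher number from compound 1 to compound 3 (0.39 log units; beyond the scatter) to point toward weaker inhibition of growth, somewhat beyond the scatter. Compound 3 is therefore estimated at 30000 nM, within a range from 8000 nM to 120000 nM.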

Compound 3, concentration for 50% growth inhibition: > 30000 nM
Compound 3 was reported as a limit; the forecaster's own chance of this, stated with the estimate: 25%; the middle value lies on the limit itself.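

In this assay, going by these compounds alone, the change from carbamoyl to carboxy gives an at least 2.4-fold higher number from compound 1 to compound 3 (0.39 log units; beyond the scatter) and so shows for the first time that growth inhibition responds to this position, with hydroxy in place of amino on a carbonyl carbon pointing toward weaker inhibition of growth. For compound 3 the entry > 30000 nM is a limit of the assay and not a number, so the step fixes only a minimum size: the limit of > 30000 nM in this assay, at which 1 of the 3 values shown sits.

From the compounds shown here alone, whether a methyl ester or a longer chain in this place would keep the activity of compound 1 stays open. So does the contribution of the rest of the core, since compound 2 offers no number.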